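Swapping a Chain Amine for a Ring Amine

The source may report more compounds than this note shows. Statements on the series, on what has been measured and on what is new or still open speak of the compounds shown alone.

Two measured compounds share one fused core and differ only in the amine sitting on a double-bonded ring carbon. Compound 1 `O=C1C=C(NC2CCCC2)C(=O)c2c1nc1n2[C@H]2OC[C@@H](O)[C@H]2OC1` carries a cyclopentylamino group. In a functional assay on MGC-803 cells (Homo sapiens) for inhibition, read by sulforhodamine B assay (on this read-out lower numbers stand for stronger inhibition and higher numbers for weaker inhibition), compound 1 reaches only a limit of the assay, > 8000 nM. Compound 2 `CCCN(CCC)C1=CC(=O)c2nc3n(c2C1=O)[C@H]1OC[C@@H](O)[C@H]1OC3` carries a dipropylamino group instead. In this assay compound 2 likewise reaches only a limit, > 16000 nM. The step that the two limits leave unreadable from compound 1 to compound 2 therefore cannot be sized, because of the limit of > 16000 nM in this assay, at which 1 of the 2 values shown sits, and (the limit of > 8000 nM in this assay, at which 1 of the 2 values shown sits). Compound 3 `O=C1C=C(N2CCCC2)C(=O)c2c1nc1n2[C@H]2OC[C@@H](O)[C@H]2OC1` is the next member: pyrrolidin-1-yl in place of dipropylamino on a double-bonded ring carbon. Among the compounds with values here, no measured step bears on this change in a readable way, so no direction beyond the scatter can be argued from the numbers; both neighbours sit at limits, and compound 3 is expected to remain weak as well. The estimate for compound 3 in this assay is 12000 nM, within 2500 nM to 60000 nM. That number is expected to mean a step of an at least 1.3-fold lower number from compound 2 to compound 3 (0.12 log units; that floor lies within the scatter).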

Compound 3, half-maximal inhibitory concentration: > 16000 nM
Compound 3 was reported as a limit; the forecaster's own chance of this, stated with the estimate: 65%; middle value at least 1.3-fold (0.12 log units) from the limit.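

In this assay compound 3 also reaches only a limit, > 16000 nM. The steps linking compound 1, compound 2 and compound 3 therefore cannot be read. Left open is how strongly any of the three inhibits, and whether swapping these amines changes that at all.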